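The source may report more compounds than this note shows. Statements on the series, on what has been measured and on what is new or still open speak of the compounds shown alone.

In an ADME assay on microsomes from liver (Homo sapiens) for metabolic stability (a higher number here means faster removal of the compound, a lower number slower removal), compound 1 `CCCC(Oc1ccc(-n2cc3ccccc3n2)cc1)c1ccc(C(=O)NCCC(=O)O)cc1` gives 44 mL/min/kg and compound 2 `O=C(O)CCNC(=O)c1ccc(C(Oc2ccc(-n3cc(C(F)(F)F)cn3)cc2)C2CCCC2)cc1` gives 22 mL/min/kg, two values that lie within the scatter of each other. Compound 3 `CCCC(Oc1ccc(-n2cc3c(n2)CCCC3)cc1)c1ccc(C(=O)NCCC(=O)O)cc1` differs from compound 1 in one place: a group of 9 heavy atoms (7 carbon, 2 nitrogen; one five-membered aromatic ring with 2 hetero atoms, one six-membered non-aromatic ring of carbon only) in place of a group of 9 heavy atoms (7 carbon, 2 nitrogen; one five-membered aromatic ring with 2 hetero atoms, one six-membered aromatic ring of carbon only), on an aromatic carbon. The change sits on an aromatic carbon, para to a large group, and the six-membered aromatic ring of carbon only gives way to a six-membered non-aromatic ring of carbon only. Among the measured compounds shown here, no step between measured compounds is available as a guide. The estimated step of a 1.1-fold higher number from compound 1 to compound 3 (0.06 log units; within the scatter) is a small upward one, expected to stay within the scatter. For compound 3 the expected clearance is 50 mL/min/kg, with an estimated range of 28 mL/min/kg to 85 mL/min/kg.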

Compound 3, clearance: 48 mL/min/kg
For compound 3 the middle estimate is 1.0-fold (0.02 log units) above the measured one; low and high end bracket the measured number.
By their numbers in this assay, from the lowest: compounds 2, 1 and 3 (each within the scatter of the next, the first and the last beyond it).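

In this assay, the non-aromatic six-membered ring in place of the aromatic one of the 2H-indazol-2-yl group gives a 1.1-fold higher number from compound 1 to compound 3 (0.04 log units; within the scatter). At this place, on an aromatic carbon para to a large group, the two fused rings are thus not told apart by this read-out, and aromaticity of that six-membered ring is not shown to matter here. No supporting measurement bears on this result.
From the compounds shown here alone, whether an amine or a hydroxyl group on the non-aromatic ring would shift clearance remains open. Compound 2 differs from compound 1 in more than one place, so it cannot settle this.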